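Swapping a two-ring group for fluorophenyl: lipophilicity

The source may hold more compounds than are shown below. What is called first, only, known or untested is meant among the compounds shown, and "the series" means these compounds.

Of the compounds shown here, three sharing one core have been measured in a physicochemical assay for lipophilicity, at pH 7.4; on this read-out higher numbers stand for higher lipophilicity and lower numbers for lower lipophilicity. Compound 1 `CNC(=O)c1cc(C(=O)NC2CC2)cn(Cc2ccc3nc[nH]c3c2)c1=O` gives 1.2. Compound 2 `CNC(=O)c1cc(C(=O)NC2CC2)cn(Cc2cccc3cc[nH]c23)c1=O` gives 3.7. Compound 3 `CNC(=O)c1cc(C(=O)NC2CC2)cn(Cc2nccc3[nH]ccc23)c1=O` gives 1.7, the second highest of the three numbers: it sits a number 0.50 log units higher from compound 1 to compound 3 (beyond the scatter), and a number 2.00 log units lower from compound 2 to compound 3 (beyond the scatter).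

Compound 4 `CNC(=O)c1cc(C(=O)NC2CC2)cn(Cc2ccc(F)cc2)c1=O` has not yet been measured. It differs from compound 3 in one place: a group of 7 heavy atoms (6 carbon, 1 fluorine; one six-membered aromatic ring of carbon only) in place of a group of 9 heavy atoms (7 carbon, 2 nitrogen; one five-membered aromatic ring with 1 hetero atom, one six-membered aromatic ring with 1 hetero atom), on a saturated chain carbon bound to an aromatic nitrogen

Among the compounds with values here, two measured steps bear on this change. Both swap groups on the same saturated chain carbon, and both show that exchanging one two-ring group for another can move this assay a long way: a number 2.50 log units higher from compound 1 to compound 2 (beyond the scatter), and a number 2.00 log units lower from compound 2 to compound 3 (beyond the scatter). The entering 4-fluorophenyl carries no hydrogen-bond donor and no acceptor, while the leaving group carries one of each, so a rise beyond the scatter is expected, though its size is uncertain. The expected step is a number 1.10 log units higher from compound 3 to compound 4 (beyond the scatter). Compound 4 is therefore estimated at 2.8, with a likely range from 2 to 3.8.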

Compound 4, distribution coefficient: 3.2
The estimate for compound 4 lay 0.40 log units below the measured number; the range from low to high includes it.
By their numbers in this assay, from the lowest: compound 1; then compound 3; then compound 4; then compound 2.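

Compound 4 is the first compound shown with a single-ring group at this place, on a saturated chain carbon bound to an aromatic nitrogen, so a two-ring group is not needed for a high number in this assay. Going from two rings to one does not fix the direction of the change, which depends on the group that leaves: the read-out shows a number 1.50 log units higher from compound 3 to compound 4 (beyond the scatter) and a number 2.00 log units higher from compound 1 to compound 4 (beyond the scatter) but also a number 0.50 log units lower from compound 2 to compound 4 (beyond the scatter). No measurement is available here that explains these differences.

From the compounds shown here alone, how plain phenyl would compare with 4-fluorophenyl stays open, so the part played by the fluorine cannot be separated from that of the ring. Going by these compounds, the reading for a group carrying an amine or a carboxylic acid at this place also stays open.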